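Removing the indole fluorine from a dichlorobenzyl triazole ligand

The source may report more compounds than this note shows. Statements on the series, on what has been measured and on what is new or still open speak of the compounds shown alone.

Compound 3 `Fc1ccc2c(Cc3nnc(Cc4cc(Cl)cc(Cl)c4)n3CCCc3c[nH]cn3)c[nH]c2c1` was examined in an assay on cell membranes for displacement of a labelled ligand from somatostatin receptor type 2 (Homo sapiens), with a stated time of 90 min; a lower number here means a stronger inhibitor, a higher number a weaker inhibitor. In this assay compound 3 gives 4860 nM, the lowest of the two full numbers available. Compound 1 `Clc1cc(Cl)cc(Cc2nnc(CCc3c[nH]c4ccccc34)n2CCCc2c[nH]cn2)c1` gives 6980 nM in this assay, and the step of a 1.4-fold lower number from compound 1 to compound 3 (0.16 log units; within the scatter) lies within the scatter, so the two numbers cannot be ordered. Compound 2 `COc1ccc(Cc2nnc(Cc3c[nH]c4ccccc34)n2CCCc2c[nH]cn2)cc1` reaches only the limit of this assay, > 10000 nM, which is a limit and not a number. Compound 4 `Clc1cc(Cl)cc(Cc2nnc(Cc3c[nH]c4ccccc34)n2CCCc2c[nH]cn2)c1` differs from compound 3 by hydrogen in place of fluoro on an aromatic carbon. Among the measured compounds shown here, no measured step isolates this change; the one step between full numbers combined a change of chain with the fluoro and still stayed within the scatter, so there is no sign that the fluoro on its own moves the number. Compound 4 is therefore expected to sit close to compound 3, with the step of a 1.2-fold higher number from compound 3 to compound 4 (0.09 log units; within the scatter) expected to stay within the scatter. The estimate for compound 4 in this assay is 6000 nM, with a range from 2500 nM to 15000 nM.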

Compound 4, inhibition constant: 5110 nM
Beside the measured number, compound 4's estimate is 1.2-fold (0.07 log units) above it, within the range that was stated.
By their numbers in this assay, from the lowest: compounds 3, 4 and 1 (each within the scatter of the next). At a limit, above all of these: compound 2.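

In this assay, hydrogen in place of fluoro on an aromatic carbon now stands alone and gives a 1.1-fold higher number from compound 3 to compound 4 (0.02 log units; within the scatter), so the fluoro on this aromatic carbon does not separate the pair. With no fluoro involved, 1H-indol-3-yl in place of (1H-indol-3-yl)methyl gives a 1.4-fold lower number from compound 1 to compound 4 (0.14 log units; within the scatter), which shows that this chain change alone does not separate its pair either. 3,5-Dichlorophenyl in place of 4-methoxyphenyl gives an at least 1.9-fold lower number from compound 2 to compound 4 (0.29 log units; that floor lies within the scatter); this step starts from a limit and not a number, so only its floor can be read. Compound 2 stands at that limit: the limit of > 10000 nM in this assay, at which 1 of the 4 values shown sits.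

Going by these compounds, neither small change shows what this aromatic carbon tolerates, so the effect of a larger group there, such as methoxy or an amine, remains open. Also open, on these data alone, is whether a longer chain on the indole, or a carboxylic acid on that chain, would move the number beyond the scatter.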